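Swapping Sulfamoyl for Fluoro: A Large Gain Expected

The source may report more compounds than this note shows. Statements on the series, on what has been measured and on what is new or still open speak of the compounds shown alone.

Compound 3 `CC(=O)Nc1ccc(S(=O)(=O)NNc2ccc(S(N)(=O)=O)cc2)cc1` stands highest of the three numbers measured in an assay for inhibition of Indoleamine 2,3-dioxygenase 1 (Homo sapiens), read by spectrophotometry, with stated times of 1 h and 4 h (on this read-out lower numbers stand for stronger inhibition and higher numbers for weaker inhibition), giving 2480 nM. Compound 1 `CC(=O)Nc1ccc(S(=O)(=O)NNc2ccccc2)cc1` gives 71 nM and compound 2 `CC(=O)Nc1ccc(S(=O)(=O)NNc2ccc(C)cc2)cc1` gives 51 nM. Compound 4 `CC(=O)Nc1ccc(S(=O)(=O)NNc2ccc(F)cc2)cc1` differs from compound 3 by fluoro in place of sulfamoyl on an aromatic carbon. For the measured compounds named here, two measured steps bear on this change: a 35-fold higher number from compound 1 to compound 3 (1.54 log units; beyond the scatter) and a 49-fold higher number from compound 2 to compound 3 (1.69 log units; beyond the scatter). Both show that placing sulfamoyl on that aromatic carbon raised the number sharply, while hydrogen and methyl gave numbers within the scatter of each other. Removing sulfamoyl and placing fluoro is therefore expected to reverse most of that rise, a large drop in this assay, a 41-fold lower number from compound 3 to compound 4 (1.62 log units; beyond the scatter). Compound 4 is estimated at 60 nM, within a range of 25 nM to 150 nM.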

Compound 4, half-maximal inhibitory concentration: 79 nM
Compound 4: middle estimate off by 1.3-fold (0.12 log units), on the low side; low and high end bracket the measured number.
By their numbers in this assay, from the lowest: compounds 2, 1 and 4 (each within the scatter of the next); then compound 3.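

In this assay the loss seen with sulfamoyl at this position is not shared by fluoro, which shows a 31-fold lower number from compound 3 to compound 4 (1.50 log units; beyond the scatter) and so recovers nearly everything sulfamoyl lost. Fluoro also fits with hydrogen and methyl, given a 1.1-fold higher number from compound 1 to compound 4 (0.05 log units; within the scatter) and a 1.5-fold higher number from compound 2 to compound 4 (0.19 log units; within the scatter) as steps within the scatter, so these three cannot be told apart here and sulfamoyl alone stands out.

From the compounds shown here alone, whether an amine or a carboxylic acid at this place would behave like fluoro or like sulfamoyl stays open. Nothing shown explains the sulfamoyl result.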